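This account rests on a few compounds, and the source may have more. Where it says the series, first, only, none or still open, it means among the compounds named here.

Compound 1 `Nc1nc(N)c(-c2ccc(NCc3csc(Cl)c3)cc2)c(COCc2ccccc2)n1` gives 170 nM in a functional assay on CHOK cells for antagonist activity at growth hormone secretagogue receptor type 1 (Homo sapiens), read by calcium flux; on this read-out lower numbers stand for stronger inhibition and higher numbers for weaker inhibition; compound 2 `Nc1nc(N)c(-c2ccc(NCc3ccncc3)cc2)c(COCc2ccccc2)n1` gives 86 nM in this assay.

Compound 2 shows the lower of the two numbers, although a 2.0-fold lower number from compound 1 to compound 2 (0.30 log units; within the scatter) lies within the scatter. Compound 3 `CC(C)(C)CNc1ccc(-c2c(N)nc(N)nc2COCc2ccccc2)cc1` differs from compound 2 by tert-butyl in place of pyridin-4-yl on a saturated chain carbon bound to a nitrogen on an aromatic ring. The only measured step at this position is a 2.0-fold lower number from compound 1 to compound 2 (0.30 log units; within the scatter), and it did not move the number beyond the scatter; a second change at the same place gives no shown ground to expect more. Compound 3 is therefore estimated at 120 nM, with a range of 40 nM to 400 nM, an expected step of a 1.4-fold higher number from compound 2 to compound 3 (0.14 log units; within the scatter) in this assay.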

Compound 3, half-maximal inhibitory concentration: 700 nM
Compound 3: middle estimate off by 5.8-fold (0.77 log units), on the low side; measured number above the stated range.
By their numbers in this assay, from the lowest: compounds 2 and 1 (each within the scatter of the next); then compound 3.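

In this assay, compound 3 shows that this position does not accept every group alike: an 8.1-fold higher number from compound 2 to compound 3 (0.91 log units; beyond the scatter) and a 4.1-fold higher number from compound 1 to compound 3 (0.61 log units; beyond the scatter) both lie beyond the scatter, unlike the earlier exchange of one aromatic ring for another. Each of these steps replaces a ring-bearing group with tert-butyl, which has no ring, and each gives weaker inhibition.

Whether the loss of the aromatic ring accounts for this stays open, and a cyclohexyl group at the same place would test that. Nothing given here speaks to the cause of the rise.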